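The compounds below may be only part of what the source reports. "The series", "measured", "known", "first", "only" and "open" are said of these compounds alone.

For the measured compounds named here, in a functional assay on DU-145 cells (Homo sapiens) for cytotoxicity, read by MTT assay, with a stated time of 72 h (a lower number here means a stronger inhibitor, a higher number a weaker inhibitor), compound 1 `COc1cc(C(=O)c2cc(OC)c(OC)c(OC)c2)cc(NC(=O)/C=C/c2cc(OC)c(OC)c(OC)c2)c1OC` gives 6600 nM and compound 2 `C#CCOc1cccc(/C=C/C(=O)Nc2cc(C(=O)c3cc(OC)c(OC)c(OC)c3)cc(OC)c2OC)c1` gives 13500 nM, the higher of these two numbers, the single step being a 2.0-fold higher number from compound 1 to compound 2 (0.31 log units; beyond the scatter). Compound 3 `COc1cc(C(=O)c2cc(OC)c(OC)c(OC)c2)cc(NC(=O)/C=C/c2ccc(C(F)(F)F)cc2)c1OC` differs from compound 2 by 4-(trifluoromethyl)phenyl in place of 3-(propargyloxy)phenyl on a double-bonded chain carbon bound to a double-bonded chain carbon. Going by the values given here, no measured step covers this change; the one known step only shows that swapping this aryl group moves the number modestly. Compound 3 is therefore expected near compound 2, with a step of about a 1.1-fold higher number from compound 2 to compound 3 (0.05 log units; within the scatter) in this assay. The estimate for compound 3 is 15000 nM, within 5000 nM to 45000 nM.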

Compound 3, half-maximal inhibitory concentration: 5100 nM
Compound 3: middle estimate off by 2.9-fold (0.47 log units), on the high side; the measured number falls inside the stated range.
By their numbers in this assay, from the lowest: compounds 3 and 1 (each within the scatter of the next); then compound 2.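

The aryl group on this double-bonded chain carbon can lose all its oxygen atoms without a measurable penalty: 4-(trifluoromethyl)phenyl in place of 3,4,5-trimethoxyphenyl stays within the scatter in this assay (a 1.3-fold lower number from compound 1 to compound 3 (0.11 log units; within the scatter)). The same group in place of 3-(propargyloxy)phenyl wins back what that group gave up (a 2.6-fold lower number from compound 2 to compound 3 (0.42 log units; beyond the scatter)), so the earlier rise goes with the propargyloxy-bearing ring, not with simply losing the methoxy groups. Nothing measured here explains these differences.

On these data alone, whether a phenyl ring carrying an amine or a carboxylic acid would fit in this place remains open.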